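The source may hold more compounds than are shown below. What is called first, only, known or untested is meant among the compounds shown, and "the series" means these compounds.

In a functional assay on A549 cells (Homo sapiens) for cytotoxicity, read by MTT assay, with a stated time of 72 h (on this read-out lower numbers stand for stronger inhibition and higher numbers for weaker inhibition), three compounds have been measured: compound 1 `O=C(N/N=C/c1ccc(O)c(Br)c1)Nc1cc2c(Nc3ccc(F)c(Cl)c3)ncnc2cc1O[C@H]1CCOC1` gives 4310 nM, compound 2 `CC(C)(C)c1cc(/C=N/NC(=O)Nc2cc3c(Nc4ccc(F)c(Cl)c4)ncnc3cc2O[C@H]2CCOC2)cc(C(C)(C)C)c1O` gives 19000 nM, and compound 3 `COc1cc2ncnc(Nc3ccc(F)c(Cl)c3)c2cc1NC(=O)N/N=C/c1ccc(O)c(Br)c1` gives 28600 nM.

Compound 3 differs from compound 1 by methyl in place of oxolan-3-yl on an oxygen on an aromatic ring. That change produced a 6.6-fold higher number from compound 1 to compound 3 (0.82 log units; beyond the scatter). The values of compound 2 and compound 3 lie within the usual scatter of each other, whereas compound 1 and compound 2 lie apart beyond it, with the lower number belonging to compound 1. The difference between the cores of compound 1 and compound 2 is not broken down here.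

Compound 4 `COc1cc2ncnc(Nc3ccc(F)c(Cl)c3)c2cc1NC(=O)N/N=C/c1cc(C(C)(C)C)c(O)c(C(C)(C)C)c1` differs from compound 2 by methyl in place of oxolan-3-yl on an oxygen on an aromatic ring. The surroundings of the place are the same word for word as between compound 1 and compound 3, so this is the same change. Among the compounds with values here, the step from compound 2 to compound 4 is therefore expected to be a 3.7-fold higher number from compound 2 to compound 4 (0.57 log units; beyond the scatter), an expectation resting on the single earlier instance of a 6.6-fold higher number from compound 1 to compound 3 (0.82 log units; beyond the scatter); with only one precedent the range is kept wide. Compound 4 is estimated to give 70000 nM in this assay, most likely between 20000 nM and 200000 nM.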

Compound 4, half-maximal inhibitory concentration: 37100 nM
Beside the measured number, compound 4's estimate is 1.9-fold (0.28 log units) above it, and the stated range covers the measured number.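

In this assay, methyl in place of oxolan-3-yl on the oxygen gives a 2.0-fold higher number from compound 2 to compound 4 (0.29 log units; within the scatter), a step that stays within the usual scatter of repeated measurements on this core. The same change therefore did not carry over at the same size from one core to the other: the same change on two cores in this assay, a 6.6-fold higher number (0.82 log units; beyond the scatter) from compound 1 to compound 3 and a 2.0-fold higher number (0.29 log units; within the scatter) from compound 2 to compound 4, 3.4-fold (0.53 log units) apart, beyond the scatter of two such steps. This shows that, for these two pairs, the size of the step cannot be taken from one core and applied unchanged to the other, but it does not show what in the cores sets the size of the step, and two pairs give no rule for a third core.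

Among the compounds shown, only oxolan-3-yl and methyl stand on that oxygen, so it remains open how an ethyl group, a longer chain ending in an amine, or a chain ending in a carboxylic acid would read in this assay. Also open, going by these compounds, is how large the step from oxolan-3-yl to methyl would be on any further core.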